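Ethoxy for Methyl on a Hydrazone Acid Series

This account rests on a few compounds, and the source may have more. Where it says the series, first, only, none or still open, it means among the compounds named here.

Compound 1 `CC1CC/C(=N\Nc2cccc(Cl)c2)c2ncc(C(=O)O)c(=O)n21` gives in a functional assay on the whole organism for inhibition, with Rattus norvegicus as the target (on this read-out lower numbers stand for an effect already at smaller amounts and higher numbers for an effect only at larger amounts of compound), only a limit, > 100 umol/kg.
Compound 2 `CC(=O)c1cccc(N/N=C2\CCC(C)n3c2ncc(C(=O)O)c3=O)c1` gives in this assay only a limit, > 1000 umol/kg.

Both measured values are limits of this assay rather than numbers, so the step that the two limits leave unreadable from compound 1 to compound 2, acetyl in place of chloro on an aromatic carbon, cannot be sized: the limit of > 100 umol/kg in this assay, at which 1 of the 2 values shown sits, and the limit of > 1000 umol/kg in this assay, at which 1 of the 2 values shown sits, leave it unreadable. Compound 2 therefore stands only at a limit, with no measured number beneath it.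

Compound 3 `CCOC(=O)c1cccc(N/N=C2\CCC(C)n3c2ncc(C(=O)O)c3=O)c1` differs from compound 2 by ethoxy in place of methyl on a carbonyl carbon. Among the compounds with values here, no measured step touches this change, and the single step between the measured compounds gives no readable size, so nothing supports an expectation of movement beyond the scatter in this assay. The step from compound 2 to compound 3 is therefore expected to be a number no higher from compound 2 to compound 3 (the limit leaves the size open). For compound 3 the estimated value in this assay is 1000 umol/kg, in the range 300 umol/kg to 3000 umol/kg, most likely reported again only as a limit.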

Compound 3, dose for 50% inhibition: > 100 umol/kg
Compound 3: only a limit was reported; the forecaster's own chance of this, stated with the estimate: 80%; the middle value is on the limit's open side.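

In this assay compound 3 gives only a limit, > 100 umol/kg, so its steps from compound 1 and compound 2, which also stand at limits, cannot be read. The compounds shown leave open whether chloro, acetyl or ethoxycarbonyl on the aromatic carbon makes any difference in this assay.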